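The compounds below may be only part of what the source reports. "The series", "measured", "known", "first", "only" and "open" are said of these compounds alone.

Working notes. Among the compounds with values here, compound 1 `C=C1C(=O)[C@]23C[C@@]1(O)CC[C@H]2c1ccc(O)c(C)c1[C@@H]3Cn1cc(-c2ccccc2)nn1` carries a phenyl-substituted triazole on the shared core; in a functional assay on A549 cells (Homo sapiens) for cytotoxicity, read by MTT assay, with a stated time of 4 days (a higher number here means a weaker inhibitor, a lower number a stronger inhibitor), compound 1 gives 1160 nM, the only plain number in hand. Compound 2 `COc1ccc(-c2cn(C[C@H]3c4c(ccc(OS(=O)(=O)c5ccc(C)cc5)c4C)[C@@H]4CC[C@@]5(C)C[C@]43CC5=O)nn2)cc1` returns only a limit in this assay, reported as > 20000 nM. That value sits at the limit of > 20000 nM in this assay, at which 1 of the 2 values shown sits. Compound 3 `C=C1C(=O)[C@]23C[C@@]1(O)CC[C@H]2c1ccc(O)c(C)c1[C@@H]3Cn1cc(-c2ccc(Cl)cc2)nn1` differs from compound 1 by chloro in place of hydrogen on an aromatic carbon. Within the data shown here, no measured pair tracks this change, so the step expected in this assay from compound 1 to compound 3 is a 1.3-fold lower number from compound 1 to compound 3 (0.11 log units; within the scatter), not beyond the usual scatter. Compound 3 is estimated at 900 nM, within 350 nM to 2500 nM.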

Compound 3, half-maximal inhibitory concentration: 640 nM
Compound 3: the middle estimate sits 1.4-fold (0.15 log units) above what was measured; the measured number falls inside the stated range.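

Going from phenyl to 4-chlorophenyl on the triazole of the shared core gives a 1.8-fold lower number from compound 1 to compound 3 (0.26 log units; within the scatter) in this assay. Within the data shown here, this is the first reading at this aromatic carbon, para to a large group, and it shows that chloro in place of hydrogen leaves the number within the scatter. Nothing in hand bears on the size of this step.

Still open, from the compounds shown here alone, is how this assay reads with an amine or a carboxylic acid in place of the chloro on this ring.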